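Cyclohexyl in place of sec-butyl: working notes

This account rests on a few compounds, and the source may have more. Where it says the series, first, only, none or still open, it means among the compounds named here.

- Compound 1 `CCC(C)NC(=C\C(=O)/C=C/c1ccc(O)c(OC)c1)/C=C/c1ccc(O)c(OC)c1`: > 25000 nM
- Compound 2 `CC(C)CNC(=C\C(=O)/C=C/c1ccc(O)cc1)/C=C/c1ccc(O)cc1`: > 25000 nM
- Compound 3 `COc1cc(/C=C/C(=O)/C=C(/C=C/c2ccc(OC(C)=O)c(OC)c2)NCC(C)C)ccc1OC(C)=O`: > 25000 nM

These entries come from an ADME assay on Caco-2 cells (Homo sapiens) for inhibition, read by sulforhodamine B assay, with a stated time of 72 h (on this read-out higher numbers stand for weaker inhibition and lower numbers for stronger inhibition), and each is a limit and not a number. Compound 1 stands at the limit of > 25000 nM in this assay, at which 3 of the 3 values shown sit. It therefore offers no number from which to measure a step.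

Compound 4 `COc1cc(/C=C/C(=O)/C=C(/C=C/c2ccc(O)c(OC)c2)NC2CCCCC2)ccc1O` keeps the core of compound 1 and carries cyclohexyl in place of sec-butyl on an amine nitrogen. Among the compounds with values here, no measured pair in the set tests a change at this place, so what follows is expectation only. No step beyond the scatter is expected in this assay, and a further limit is the likeliest report. Should a number appear, it is expected to lie close to the limit that compound 1 reached. The estimate amounts to a step that the limit leaves unreadable from compound 1 to compound 4, an expected change that stays within the usual scatter. The estimate for compound 4 is 28000 nM, expected to fall between 12000 nM and 50000 nM.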

Compound 4, half-maximal inhibitory concentration: > 25000 nM
Compound 4 was reported as a limit; the forecaster's own chance of this, stated with the estimate: 65%; the middle value does not contradict the limit.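

Compound 1 and compound 4 both stand as limits, so no step between them can be read: the limit of > 25000 nM in this assay, at which 4 of the 4 values shown sit.

The compounds shown leave open whether any group on the amine nitrogen of the shared core gives a measurable value in this assay.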